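Methyl in place of hydrogen on compound 1

This account rests on a few compounds, and the source may have more. Where it says the series, first, only, none or still open, it means among the compounds named here.

- compound 1 `O=C(O)Cn1nc(Cn2cc3cc(OCC4CC4)c(Cl)cc3n2)c2ccccc2c1=O` gives 69 L/kg
- compound 2 `O=C(O)Cc1nn(Cc2cn3cc(OCC4CC4)c(Cl)cc3n2)c2ccccc2c1=O` gives 18 L/kg

In an ADME assay on the whole organism (Mus musculus, strain CD1) for pharmacokinetics, read by LC-MS, with a stated time of 24 h, at a dose of 1 mg/kg by the intravenous route (on this read-out higher numbers stand for wider distribution into tissues and lower numbers for narrower distribution), compound 1 gives 69 L/kg and so stands highest of the two measured compounds. Compound 2 gives 18 L/kg on the same read-out, and that gap lies beyond the usual scatter. Compound 3 `C[C@H](C(=O)O)n1nc(Cn2cc3cc(OCC4CC4)c(Cl)cc3n2)c2ccccc2c1=O` has not yet been measured. It departs from compound 1 by methyl in place of hydrogen on a saturated chain carbon bound to an aromatic nitrogen and a carbonyl carbon, so that carboxymethyl becomes 1-carboxyethyl. Within the data shown here, no two measured compounds differ in one place only, so the data hold no direct guide to the size of this change. The expectation therefore starts from compound 1 at 69 L/kg and assumes a change that stays inside the usual scatter of this assay, with no firm direction. The expected shift is a 1.3-fold lower number from compound 1 to compound 3 (0.10 log units; within the scatter) and marks only a tentative lean toward a lower number. Compound 3 is estimated at 55 L/kg (expected range 22 L/kg to 130 L/kg).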

Compound 3, volume of distribution at steady state: 168 L/kg
Beside the measured number, compound 3's estimate is 3.1-fold (0.48 log units) below it; the whole stated range lies below it.
By their numbers in this assay, from the lowest: compound 2; then compound 1; then compound 3.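

In this assay, among these compounds, replacing carboxymethyl with 1-carboxyethyl gives a 2.4-fold higher number from compound 1 to compound 3 (0.39 log units; beyond the scatter), the first change in one place that can be read, and it lies beyond the scatter. The saturated chain carbon bound to an aromatic nitrogen and a carbonyl carbon is therefore not a silent position on this read-out: a single added carbon, with no ring, no hydrogen-bond donor or acceptor and no net charge, is enough to move the number upward, although the step is modest in size. Nothing measured here gives a reason for this shift in distribution, so the step stands as an observation on one pair of compounds only.

The compounds shown leave open whether the opposite configuration at this carbon, an ethyl or other longer chain, or a second methyl on the same carbon would carry the number further, hold it or reverse it. They also leave open whether methyl in place of hydrogen would give a step of similar direction and size on the core of compound 2.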